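Replacing a Piperidine Tail with Methylpiperazine on a Quinoline Amide

This account rests on a few compounds, and the source may have more. Where it says the series, first, only, none or still open, it means among the compounds named here.

Of the compounds shown here, two have been measured so far. Compound 1 `COc1cc2c(Oc3ccc(NC(=O)c4nn(-c5ccccc5)c(=O)cc4C)cc3F)ccnc2cc1OCCCN1CCN(C)CC1` gives 350 nM in a functional assay on A549 cells (Homo sapiens) for inhibition, read by MTT assay, with a stated time of 72 h (on this read-out higher numbers stand for weaker inhibition and lower numbers for stronger inhibition), while compound 2 `COc1cc2c(Oc3ccc(NC(=O)c4nn(-c5ccccc5C)c(=O)cc4C)cc3F)ccnc2cc1OCCCN1CCCCC1` gives 1920 nM in this assay. Within the data shown here, compound 2 therefore stands at the highest of the two numbers, and the only other value, that of compound 1, is beyond the scatter of repeated measurements. These two compounds differ in two places at once, so the two values alone cannot say which change carries the difference.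

Compound 3 `COc1cc2c(Oc3ccc(NC(=O)c4nn(-c5ccccc5C)c(=O)cc4C)cc3F)ccnc2cc1OCCCN1CCN(C)CC1` has not yet been measured in this assay. It differs from compound 2 in one place only: 4-methylpiperazin-1-yl in place of piperidin-1-yl on a saturated chain carbon, three bonds along the chain from an oxygen on an aromatic ring. With this change, compound 3 carries the same chain end as compound 1 and keeps the methylated phenyl of compound 2.

Since compound 1 gives 350 nM and compound 2 gives 1920 nM, the expectation is that compound 3 falls between them, with a step from compound 2 to compound 3 of a 2.6-fold lower number from compound 2 to compound 3 (0.41 log units; beyond the scatter) toward a lower number. Compound 3 is estimated at 750 nM, within a range from 250 nM to 2200 nM.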

Compound 3, half-maximal inhibitory concentration: 2830 nM
For compound 3 the middle estimate is 3.8-fold (0.58 log units) below the measured one; the whole stated range lies below it.
By their numbers in this assay, from the lowest: compound 1; then compounds 2 and 3 (each within the scatter of the next).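

In this assay, the step of a 1.5-fold higher number from compound 2 to compound 3 (0.17 log units; within the scatter) lies within the scatter, so with the methyl kept on the aromatic ring, 4-methylpiperazin-1-yl and piperidin-1-yl cannot be told apart on a saturated chain carbon, three bonds along the chain from an oxygen on an aromatic ring. With the 4-methylpiperazin-1-yl end held constant, methyl in place of hydrogen on an aromatic carbon gives an 8.1-fold higher number from compound 1 to compound 3 (0.91 log units; beyond the scatter), which lies beyond the scatter and is the only single change shown that does so. Nothing available here explains why the methyl matters while the chain-end exchange does not.

From the compounds shown here alone, it remains open whether piperidin-1-yl and 4-methylpiperazin-1-yl would also read alike on the aromatic ring without the methyl, and whether a morpholine or a dimethylamino group at the end of the chain would give a similar number. Going by these compounds, it is equally open whether a chlorine or a methoxy group in place of the methyl would carry the same penalty, so the present step describes only the methyl itself and not substitution at that aromatic carbon in general.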